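A few compounds are considered here, and "the series" means these few. Any claim that something is new, unique, unknown or untested is made for them only; others in the source may bear on it.

Measured so far:
- compound 1, `CCO/N=C/Nc1cc(Cl)c(OCOC)c(Cl)c1`: 3.7
- compound 2, `C#CCc1c(Cl)cc(N/C=N/OCCCC)cc1Cl`: 4.4

In a physicochemical assay for lipophilicity, measured as octanol-water partition (a higher number here means a more lipophilic compound, a lower number a more polar compound), compound 2 gives 4.4, the higher of the two numbers measured. The nearest measured point is compound 1, which in this assay gives 3.7, a number lower than that of compound 2 by a margin beyond the scatter. Within the data shown here, no step between two compounds that differ in a single place is available, so the two values are only compared, not traced to one change.

Compound 3, `C#CCc1c(Cl)cc(N/C=N/Oc2ccc(C)cc2)cc1Cl`, is not yet measured in this assay. Compared with compound 2 it differs in one place: 4-methylphenyl in place of butyl on an oxygen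

For this assay a step upward of moderate size is expected, more than the scatter but well short of a full unit. The estimate for compound 3 in this assay is 4.8, with a range from 4.3 to 5.4. The expected step is a number 0.40 log units higher from compound 2 to compound 3 (beyond the scatter).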

Compound 3, partition coefficient: 4.8
For compound 3 middle estimate and measured number coincide at the digits printed; the range from low to high includes it.
By their numbers in this assay, from the lowest: compound 1; then compound 2; then compound 3.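

Among these compounds, this is the first step that can be traced to a single change: on an oxygen whose other neighbours are double-bonded nitrogen, this assay reads a number 0.40 log units higher from compound 2 to compound 3 (beyond the scatter) with 4-methylphenyl in place of butyl. The change adds carbon and a six-membered aromatic ring together, while neither group carries a hydrogen-bond donor or acceptor, so this one step cannot divide the rise between added carbon and the ring. No measurement bearing on the origin of the step is available.

The compounds shown leave open whether a longer chain such as octyl on the same oxygen would match the value of compound 3, 4.8, without any ring. On these data alone, how this assay would respond to an amine or a carboxylic acid at this place also remains open.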